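Ester variation on the shared core: cytotoxicity notes

A few compounds are considered here, and "the series" means these few. Any claim that something is new, unique, unknown or untested is made for them only; others in the source may bear on it.

Measured so far:
compound 1 `C=C1C(=O)O[C@H]2CC3=C[C@H](C/C(C)=C/[C@@H](OC(=O)c4ccc(C(F)(F)F)cc4)[C@H]12)OC3=O` — > 10000 nM
compound 2 `C=C1C(=O)O[C@H]2CC3=C[C@H](C/C(C)=C/[C@@H](OC(=O)/C=C/c4ccccc4)[C@H]12)OC3=O` — > 10000 nM
compound 3 `C=C1C(=O)O[C@H]2CC3=C[C@H](C/C(C)=C/[C@@H](OC(=O)CCl)[C@H]12)OC3=O` — > 10000 nM

In a functional assay on NCI-H460 cells (Homo sapiens) for cytotoxicity, read by MTT assay, with a stated time of 48 h (a lower number here means a stronger inhibitor, a higher number a weaker inhibitor), compound 1 gives only a limit, > 10000 nM. In this assay compound 2 likewise gives only a limit, > 10000 nM. Compound 3 too reaches only a limit in this assay, > 10000 nM. All three therefore sit at the limit of > 10000 nM in this assay, at which 3 of the 3 values shown sit, and none of the exchanges on the carbonyl carbon can be sized: a step that the two limits leave unreadable from compound 1 to compound 2, a step that the two limits leave unreadable from compound 1 to compound 3 and a step that the two limits leave unreadable from compound 2 to compound 3 all stay unreadable. Compound 2 thus stands nowhere on a scale, only at the limit, and the two other values shown are limits as well.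

Compound 4 `C=C1C(=O)O[C@H]2CC3=C[C@H](C/C(C)=C/[C@@H](OC(=O)c4ccncc4)[C@H]12)OC3=O` carries the next change on the same carbonyl carbon: pyridin-4-yl in place of 2-phenylethenyl on a carbonyl carbon. Within the data shown here, no measured step bears on this exchange with a readable size, since every comparison among compounds 1, 2 and 3 ends at the limit. The step expected in this assay is accordingly a step that the limit leaves unreadable from compound 2 to compound 4, most probably again a limit rather than a number. Compound 4 is estimated at 15000 nM, within 5000 nM to 50000 nM.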

Compound 4, half-maximal inhibitory concentration: 5600 nM
Estimate against measurement, compound 4: 2.7-fold (0.43 log units) above; low and high end bracket the measured number.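

The pyridin-4-yl ester of compound 4 is the first on this carbonyl carbon to give a number rather than a limit in this assay, so a readable value is possible with the shared core unchanged: the limit of > 10000 nM in this assay, at which 3 of the 4 values shown sit.

Against the other esters the exchange reads as an at least 1.7-fold lower number from compound 2 to compound 4 (0.25 log units; that floor lies within the scatter), as an at least 1.7-fold lower number from compound 3 to compound 4 (0.25 log units; that floor lies within the scatter) and as an at least 1.7-fold lower number from compound 1 to compound 4 (0.25 log units; that floor lies within the scatter), and each of these is a floor rather than a size. Among the aromatic esters, the ring with a hetero atom in compound 4 gives a number, while the carbon-only rings of compound 1 and compound 2 stay at the limit, a contrast that rests on this one compound.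

Going by these compounds, whether the ring nitrogen or its place counts stays open, and a plain phenyl or a pyridin-3-yl on the same carbonyl carbon would separate the two. On these data alone, how a chain carrying an amine would read in this assay also stays open.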